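A few compounds are considered here, and "the series" means these few. Any claim that something is new, unique, unknown or untested is made for them only; others in the source may bear on it.

Measured so far in a functional assay on C6 cells (Rattus norvegicus) for cytotoxicity, read by MTT assay, with a stated time of 24 h, tested at 12 ug/mL; a higher number here means a weaker effect of the compound at the concentration tested, a lower number a stronger effect:
- compound 1, `Cc1nnc(SCC(=O)N/N=c2/scc(-c3ccc(Cl)cc3)n2-c2ccccc2)s1`: 76.6%
- compound 2, `O=C(CSc1nnnn1-c1ccccc1)N/N=c1/scc(-c2ccc(Cl)cc2)n1-c1ccccc1`: 69.3%

Compound 1 stands highest of the two numbers in this assay, but compound 2 sits within the usual scatter of it, so the two compounds are not told apart: a number 7.3 percentage points lower from compound 1 to compound 2 (within the scatter). That single step concerns the group on the sulfur and leaves the rest of the shared core untouched.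

Compound 3, `Cc1ccc(-c2cs/c(=N/NC(=O)CSc3nnc(C)s3)n2-c2ccccc2)cc1`, has not been measured in this assay. It differs from compound 1 as follows: methyl in place of chloro on an aromatic carbon. Cut one bond further out, the same difference reads 4-chlorophenyl to 4-methylphenyl.

Among the measured compounds shown here, no measured step touches that part of the molecule. For the measured compounds named here, the only step available, the exchange on the sulfur from compound 1 to compound 2, is itself within the scatter, and it says nothing about the six-membered aromatic ring of carbon only. Without a comparison at that place, the expectation for this assay is a step no larger than the scatter, in no particular direction: a number 1.6 percentage points lower from compound 1 to compound 3 (within the scatter) is expected.

Compound 3 is therefore estimated at 75% in this assay, within a range of 58% to 92%.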

Compound 3, a percentage reported as activity, at one concentration (the size of the read-out at that concentration, not a potency): 58.3%
Beside the measured number, compound 3's estimate is 16.7 percentage points above it; the range from low to high includes it.
By their numbers in this assay, from the lowest: compound 3; then compounds 2 and 1 (each within the scatter of the next).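

In this assay the ring carrying the chloro group proves to be a place where one change moves the read-out beyond the scatter: a number 18.3 percentage points lower from compound 1 to compound 3 (beyond the scatter) when 4-chlorophenyl becomes 4-methylphenyl. Since a lower number means a stronger effect at the concentration tested, this change gives the series its first separated pair, whereas the exchange on the sulfur gave only a number 7.3 percentage points lower from compound 1 to compound 2 (within the scatter) and did not tell its two compounds apart. The swap replaces one heavy atom with one heavy atom, with no ring, hydrogen-bond donor, hydrogen-bond acceptor or net charge involved on either side, so even a change this small on an aromatic carbon, para to a large group, registers in this series, although nothing at hand accounts for the difference.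

The compounds shown leave open whether an amine or a methoxy group at this same place would carry the number lower still or bring it back towards that of compound 1. They also leave open whether 4-methylphenyl would lower the number to a similar extent with 1-phenyl-1H-tetrazol-5-yl on the sulfur.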